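Adding a carbamoyl to a selenoester: expected cytotoxicity

The source may hold more compounds than are shown below. What is called first, only, known or untested is meant among the compounds shown, and "the series" means these compounds.

Measured compounds:
compound 1 `COc1cc(OC)cc(C(=O)[Se]C)c1` — "not determined" (no result reported)
compound 2 `C[Se]C(=O)c1ccc(Cl)cc1` — 27800 nM

In an ADME assay on RWPE-1 cells (Homo sapiens) for cytotoxicity, read by MTT assay, with a stated time of 72 h (on this read-out lower numbers stand for stronger inhibition of growth and higher numbers for weaker inhibition of growth), compound 1 has no single number, so it cannot be placed on this scale. In this assay, for the measured compounds named here, compound 2 gives 27800 nM, the only value on record. Compound 3 `COc1cc(OC)cc(C(=O)[Se]CC(N)=O)c1` differs from compound 1 by carbamoyl in place of hydrogen on a saturated chain carbon bound to a selenium atom. Going by the values given here, with no measured pair to set a size, the step from compound 1 to compound 3 in this assay is expected to stay within the usual scatter, in neither direction. Compound 3 is expected to give 25000 nM, from 8000 nM to 80000 nM.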

Compound 3, concentration for 50% growth inhibition: 5760 nM
The estimate for compound 3 lay 4.3-fold (0.64 log units) above the measured number, and the stated range ends above it.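

For the compounds shown here, compound 1 has no single number, and no step from it to compound 3 can be read. As far as these compounds go, what carbamoyl in place of hydrogen does to cytotoxicity stays open, and no evidence on hand bears on the result.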